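The compounds below may be only part of what the source reports. "The series", "measured", "known", "first", "only" and "open" are said of these compounds alone.

Measured so far:
- compound 1, `CCN(CC)S(=O)(=O)c1ccc(S(=O)(=O)N2CCC[C@@H](C(=O)NC)C2)cc1`: 2000 nM
- compound 2, `CCN(CC)S(=O)(=O)c1ccc(S(=O)(=O)N2CCC[C@@H](C(=O)NC3CN(C(=O)OC(C)(C)C)C3)C2)cc1`: 100 nM

In a functional assay on MIA PaCa-2 cells (Homo sapiens) for inhibition, read by MTT assay, with a stated time of 3 days (on this read-out lower numbers stand for stronger inhibition and higher numbers for weaker inhibition), compound 1 gives 2000 nM, while compound 2 gives 100 nM. Among the measured compounds shown here, compound 2 thus holds the lowest of the two numbers, and the only measured step, a 20-fold lower number from compound 1 to compound 2 (1.30 log units; beyond the scatter), separates it from compound 1 by a margin well beyond the scatter.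

Compound 3, `CCN(CC)S(=O)(=O)c1ccc(S(=O)(=O)N2CCC[C@@H](C(=O)NC3CN(C(=O)NC(C)(C)C)C3)C2)cc1`, keeps the whole of compound 2 apart from one change: (tert-butyl)amino in place of tert-butoxy on a carbonyl carbon. Put another way, tert-butoxycarbonyl becomes (tert-butyl)carbamoyl on the azetidine nitrogen. For the measured compounds named here, no measured step bears directly on this change; the one step known, a 20-fold lower number from compound 1 to compound 2 (1.30 log units; beyond the scatter), concerns the substituent on the amide-type nitrogen, which is unchanged here, and so it gives no guidance on the size or direction of the present step. With no evidence of a shift, compound 3 is expected to stay close to compound 2, with the estimated step of a 1.5-fold higher number from compound 2 to compound 3 (0.18 log units; within the scatter) lying within the usual scatter. Compound 3 is therefore estimated at 150 nM in this assay, within a range of 50 nM to 500 nM.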

Compound 3, half-maximal inhibitory concentration: 1400 nM
Compound 3: middle estimate off by 9.3-fold (0.97 log units), on the low side, outside the stated range (above it).
By their numbers in this assay, from the lowest: compound 2; then compounds 3 and 1 (each within the scatter of the next).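

In this assay, the carbonyl carbon on the ring amide-type nitrogen proves sensitive to the atom that joins it to the tert-butyl group: (tert-butyl)amino in place of tert-butoxy, with the same count of heavy atoms, gives a 14-fold higher number from compound 2 to compound 3 (1.15 log units; beyond the scatter). The gain that came with 1-(tert-butoxycarbonyl)azetidin-3-yl in place of methyl therefore does not hold for every group of this size, since 1-((tert-butyl)carbamoyl)azetidin-3-yl in place of methyl gives only a 1.4-fold lower number from compound 1 to compound 3 (0.15 log units; within the scatter), a step that stays within the scatter. Nothing at hand explains why these two close relatives part so widely.

The swap changes the atom and also the counted hydrogen-bond donors and acceptors, so the compounds shown cannot say whether the donor on (tert-butyl)amino goes with the higher number, and (tert-butyl)(methyl)amino or methoxy on the same carbonyl carbon remain open. Also open is whether the tert-butyl group matters at all, as neither an ethyl nor a cyclopropyl group stands in its place among these compounds.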